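The source may hold more compounds than are shown below. What is called first, only, known or untested is meant among the compounds shown, and "the series" means these compounds.

Compound 2 `ClCc1ccc(Cn2cnc3nc(Cl)nc(Cl)c32)cc1` gives 2510 nM. Compound 3 `ClCc1cccc(Cn2cnc3nc(Cl)nc(Cl)c32)c1` gives 5370 nM. Compound 1 `ClCc1cccc(Cn2cnc3ncnc(Cl)c32)c1` gives 43700 nM.

In a functional assay on OVCAR-3 cells (Homo sapiens) for cytotoxicity, read by sulforhodamine B assay, with a stated time of 48 h (on this read-out lower numbers stand for higher toxicity in this test and higher numbers for lower toxicity in this test), compound 2 stands lowest of the three, with compound 3 nearest and compound 1 furthest away. Compound 4 `ClCc1ccc(Cn2cnc3ncnc(Cl)c32)cc1` differs from compound 2 by hydrogen in place of chloro on an aromatic carbon. For the measured compounds named here, one measured step bears directly on this change, being the same exchange run the other way at the same place: an 8.1-fold lower number from compound 1 to compound 3 (0.91 log units; beyond the scatter). Undoing that exchange is expected to move the number by a similar amount in the opposite direction, towards lower toxicity in this test, so for compound 4 a rise of about an 8.0-fold higher number from compound 2 to compound 4 (0.90 log units; beyond the scatter) is expected. Compound 4 is therefore estimated at 20000 nM, with a range from 7000 nM to 60000 nM.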

Compound 4, concentration lethal to 50% of the cells: 6300 nM
For compound 4 the middle estimate is 3.2-fold (0.50 log units) above the measured one; measured number outside the range, below it.
By their numbers in this assay, from the lowest: compound 2; then compounds 3 and 4 (each within the scatter of the next); then compound 1.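

Removing the chloro group from the aromatic carbon between two ring nitrogen atoms gives a 2.5-fold higher number from compound 2 to compound 4 (0.40 log units; beyond the scatter), so in this assay the direction seen earlier also holds on a second core. The size of the change does not carry over from one core to the other: the same change on two cores in this assay, an 8.1-fold lower number (0.91 log units; beyond the scatter) from compound 1 to compound 3 and a 2.5-fold lower number (0.40 log units; beyond the scatter) from compound 4 to compound 2, 3.2-fold (0.51 log units) apart, beyond the scatter of two such steps

The compounds shown leave open what an amine or a methoxy group at this place would do to the number. For the compounds shown here, with only two pairs, they also cannot tell whether the difference in size would recur on other cores.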